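A Methyl in Place of a Methoxy on the Shared Core

The source may hold more compounds than are shown below. What is called first, only, known or untested is meant among the compounds shown, and "the series" means these compounds.

The three measured compounds share one core and differ only in the fused ring attached to the carbonyl carbon. Compound 1 `COc1ccc(/C=C/c2cc(OC)cc(OC)c2/C=C/C(=O)c2cc3cccc(C)c3oc2=O)cc1` was tested in an assay on isolated protein for inhibition of Amine oxidase [flavin-containing] A (Homo sapiens), read by fluorescence, with a stated time of 15 min; on this read-out lower numbers stand for stronger inhibition and higher numbers for weaker inhibition; in that assay compound 1 reaches only the limit of > 60000 nM, which is a limit and not a number. Compound 2 `COc1ccc(/C=C/c2cc(OC)cc(OC)c2/C=C/C(=O)c2cc3cc(C)ccc3oc2=O)cc1` gives 30400 nM in this assay. Compound 3 `COc1ccc(/C=C/c2cc(OC)cc(OC)c2/C=C/C(=O)c2cc3ccc(OC)cc3oc2=O)cc1` likewise reaches only the limit of > 60000 nM. Two of the three values therefore sit at the limit of > 60000 nM in this assay, at which 2 of the 3 values shown sit, so compound 3 stands at the weak end of what has been measured. Going by the values given here, the one measured step, an at least 1.9-fold lower number from compound 1 to compound 2 (0.29 log units; that floor lies within the scatter), has a floor that lies within the scatter.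

Compound 4 `COc1ccc(/C=C/c2cc(OC)cc(OC)c2/C=C/C(=O)c2cc3ccc(C)cc3oc2=O)cc1` differs from compound 3 by methyl in place of methoxy on an aromatic carbon. Among the compounds with values here, no measured step exchanges a methyl for a methoxy, and the step from compound 1 to compound 2 is the only guide; compound 2 with its methyl yields a number rather than a limit. For compound 4 the expected shift is a number no higher from compound 3 to compound 4 (the limit leaves the size open), small and uncertain in direction. Compound 4 is estimated at 60000 nM, between 25000 nM and 150000 nM.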

Compound 4, half-maximal inhibitory concentration: 58200 nM
Compound 4: the middle estimate sits 1.0-fold (0.01 log units) above what was measured, and the stated range covers the measured number.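

Methyl in place of methoxy on this aromatic carbon gives an at least 1.0-fold lower number from compound 3 to compound 4 (0.01 log units; that floor lies within the scatter) in this assay, so the exchange yields a number where the methoxy gave a limit, without showing a change beyond the scatter. With the methyl placed elsewhere on the ring, the result is a 1.9-fold higher number from compound 2 to compound 4 (0.28 log units; within the scatter), so these two placements cannot be put in order. The floor of an at least 1.0-fold lower number from compound 1 to compound 4 (0.01 log units; that floor lies within the scatter) tells no more, and the values remain crowded at the weak end: the limit of > 60000 nM in this assay, at which 2 of the 4 values shown sit.

From the compounds shown here alone, how far the methoxy compound really lies from the methyl compound stays open. So does whether an amine or a carboxylic acid on this aromatic carbon would move the number beyond the scatter.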